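The source may report more compounds than this note shows. Statements on the series, on what has been measured and on what is new or still open speak of the compounds shown alone.

In a functional assay on HeLa cells (Homo sapiens) for cytotoxicity, read by cell counting, with a stated time of 48 h (on this read-out lower numbers stand for an effect already at smaller amounts and higher numbers for an effect only at larger amounts of compound), compound 2 (`CCCCCCCCCCCC(=O)O[C@H]1[C@H](O)[C@H](n2ccc(N)nc2=O)O[C@@H]1CO`) gives 0.08 ug/mL and compound 1 (`CCCCCCCC/C=C\CCCCCCCCCCCC(=O)O[C@H]1[C@H](O)[C@H](n2ccc(N)nc2=O)O[C@@H]1CO`) gives 0.16 ug/mL and the two lie within the scatter of each other. Compound 3 (`CCCCCCCCCCCCCCCCCCCC(=O)O[C@H]1[C@H](O)[C@H](n2ccc(N)nc2=O)O[C@@H]1CO`) extends the chain of compound 2: octyl in place of hydrogen on a saturated chain carbon, ten or more bonds along the chain from a carbonyl carbon. Among the measured compounds shown here, the one measured step that bears on this removes dec-1-en-1-yl at that kind of place, and it stays within the scatter (a 2.0-fold lower number from compound 1 to compound 2 (0.30 log units; within the scatter)). No step beyond the scatter is therefore expected in this assay. The estimated step is small (a 1.6-fold higher number from compound 2 to compound 3 (0.21 log units; within the scatter)). For compound 3 the expected value is 0.13 ug/mL (estimated range 0.05 ug/mL to 0.35 ug/mL).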

Compound 3, concentration for half-maximal effect: 0.1 ug/mL
Estimate against measurement, compound 3: 1.3-fold (0.11 log units) above; measured number inside the range.
By their numbers in this assay, from the lowest: compounds 2, 3 and 1 (each within the scatter of the next).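

Octyl in place of hydrogen on a saturated chain carbon gives a 1.3-fold higher number from compound 2 to compound 3 (0.10 log units; within the scatter) in this assay, so at this position adding chain, like removing it, has so far produced no step beyond the scatter. Octyl in place of dec-1-en-1-yl gives a 1.6-fold lower number from compound 1 to compound 3 (0.20 log units; within the scatter), so the saturated and unsaturated groups also cannot be told apart here. Nothing measured explains this result. Still open, on these data alone, is whether a much shorter chain, or an amine or carboxylic acid on that chain carbon, would give a step beyond the scatter.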